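Capping a hydroxy group with methyl

A few compounds are considered here, and "the series" means these few. Any claim that something is new, unique, unknown or untested is made for them only; others in the source may bear on it.

Measured so far in a functional assay on HuCC-A1 cells (Homo sapiens) for cytotoxicity, read by MTT assay; on this read-out lower numbers stand for stronger inhibition and higher numbers for weaker inhibition
compound 1 (`COc1cc(O)c(C=O)c2c1[C@H](O)C[C@@H](c1ccccc1)O2`): 130000 nM
compound 2 (`COc1c(C)c(OC)c2c(c1C=O)O[C@H](c1ccccc1)C[C@H]2O`): "not active" (no number reported)

Compound 1 stands alone on the numbers: its 130000 nM is the only figure available, and compound 2 has no number to set against it. Compound 3 (`COc1cc(O)c(C=O)c2c1[C@H](OC)C[C@@H](c1ccccc1)O2`) carries methyl in place of hydrogen on an oxygen on a saturated carbon, turning hydroxy to methoxy (methyl in place of hydrogen on an oxygen on a saturated carbon). Going by the values given here, no measured step shows what such a change does, so no shift beyond the scatter is expected in this assay in either direction. The expected outcome is no change at the digits printed from compound 1 to compound 3 (within the scatter) within the scatter. For compound 3 the estimated value is 130000 nM with an expected range from 50000 nM to 300000 nM as its bounds.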

Compound 3, half-maximal inhibitory concentration: 140000 nM
Estimate against measurement, compound 3: 1.1-fold (0.03 log units) below; low and high end bracket the measured number.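

In this assay, methyl in place of hydrogen on an oxygen on a saturated carbon, turning hydroxy to methoxy, gives a 1.1-fold higher number from compound 1 to compound 3 (0.03 log units; within the scatter). Going by these compounds alone, this is the first reading for this position, and it shows that this one change leaves the number within the scatter. Nothing available explains this result. The compounds shown leave open whether a longer chain on this oxygen, such as a butyl ether, would read the same way. They also leave open what an amine in place of the hydroxy would do.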